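Fluorine placement on the benzoyl arm of compound 2

This account rests on a few compounds, and the source may have more. Where it says the series, first, only, none or still open, it means among the compounds named here.

Compound 2 `CN(C(=O)NC(=O)c1ccc(F)c(F)c1)c1nc(C(F)(F)F)c(C(=O)N/N=C/c2cc(C(F)(F)F)cc(C(F)(F)F)c2)s1` gives 3.51 ug/mL in a functional assay on BCG823 cells (Homo sapiens) for inhibition, read by MTT assay, with a stated time of 72 h (a lower number here means a stronger inhibitor, a higher number a weaker inhibitor), the smallest number of the three in hand. Compound 3 `CN(C(=O)NC(=O)c1ccc(F)c(F)c1)c1nc(C(F)(F)F)c(C(=O)N/N=C/c2cccc(C(F)(F)F)c2)s1` gives 4.46 ug/mL, and the step of a 1.3-fold higher number from compound 2 to compound 3 (0.10 log units; within the scatter) stays inside the scatter. Compound 1 `CN(C(=O)NC(=O)c1ccc([N+](=O)[O-])cc1)c1nc(C(F)(F)F)c(C(=O)N/N=C/c2ccc([N+](=O)[O-])cc2)s1` gives 7.45 ug/mL, a gap from compound 2 that lies beyond the scatter. Compound 4 `CN(C(=O)NC(=O)c1c(F)cccc1F)c1nc(C(F)(F)F)c(C(=O)N/N=C/c2cc(C(F)(F)F)cc(C(F)(F)F)c2)s1` differs from compound 2 by 2,6-difluorophenyl in place of 3,4-difluorophenyl on a carbonyl carbon. Among the measured compounds shown here, no measured step touches this arm: the single step in hand, between compound 2 and compound 3, alters the other end of the molecule and is within the scatter. The data give no ground for a shift beyond the scatter in this assay from this change. Compound 4 is therefore expected to give about 3.8 ug/mL, within 1.9 ug/mL to 7.6 ug/mL. The expected step of a 1.1-fold higher number from compound 2 to compound 4 (0.03 log units; within the scatter) is within the scatter.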

Compound 4, half-maximal inhibitory concentration: 5.28 ug/mL
Compound 4: middle estimate off by 1.4-fold (0.14 log units), on the low side, and the stated range covers the measured number.
By their numbers in this assay, from the lowest: compounds 2, 3, 4 and 1 (each within the scatter of the next, the first and the last beyond it).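

In this assay the arm on the carbonyl carbon now has its first measured step (a 1.5-fold higher number from compound 2 to compound 4 (0.18 log units; within the scatter)), for 2,6-difluorophenyl in place of 3,4-difluorophenyl. Rearranging the two fluorines on this ring thus shifts the number no further than the scatter, and the two compounds cannot be ordered. No measurement in hand offers an explanation for this result.

Going by these compounds, whether methoxy or an amine on this ring, or cyclohexyl in place of it, would shift the number beyond the scatter stays open. Compound 1 differs from compound 2 in more than one place, so its gap cannot be assigned to this arm.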